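This account rests on a few compounds, and the source may have more. Where it says the series, first, only, none or still open, it means among the compounds named here.

Of the compounds shown here, two built on one shared core have so far been measured in a functional assay on CCRF-CEM cells (Homo sapiens) for antiproliferative activity, read by MTT assay, with a stated time of 24 h, tested at 100 uM; on this read-out higher numbers stand for a weaker effect at the one concentration tested and lower numbers for a stronger effect. Compound 1, `OC(CCn1nc2c(Br)c(Br)c(Br)c(Br)c2n1)c1ccccc1`, gives in this assay a value of 21%. Compound 2, `C[C@H](O)CCn1nc2c(Br)c(Br)c(Br)c(Br)c2n1`, gives in this assay a value of 36%. On these two numbers compound 2 stands highest; its nearest neighbour is compound 1, which lies beyond the scatter below it, so compound 2 shows the weaker effect of the pair at the single concentration tested. Compound 3, `OCC(O)Cn1nc2c(Br)c(Br)c(Br)c(Br)c2n1`, has not yet been measured in this assay. It differs from compound 2 in a single place: 1,2-dihydroxyethyl in place of 2-hydroxypropyl on a saturated chain carbon bound to an aromatic nitrogen. Among the compounds with values here, no step between measured compounds is available to guide the expectation, since compound 1 and compound 2 differ from each other in more than one place. For the step from compound 2 to compound 3 a small rise is expected, of the size a number 8 percentage points higher from compound 2 to compound 3 (within the scatter), which may well stay within the scatter. Compound 3 is therefore estimated to give in this assay about 44%, within a range from 25% to 68%.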

Compound 3, a percentage reported as activity, at one concentration (the size of the read-out at that concentration, not a potency): 8%
For compound 3 the middle estimate is 36 percentage points above the measured one, and the stated range ends above it.
By their numbers in this assay, from the lowest: compound 3; then compound 1; then compound 2.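

In this assay, putting 1,2-dihydroxyethyl in place of 2-hydroxypropyl on a saturated chain carbon bound to an aromatic nitrogen gives a number 28 percentage points lower from compound 2 to compound 3 (beyond the scatter), so the effect at the one concentration tested becomes stronger with this change. Within the data shown here, this is the first change in a single place to be read at this position, and it shows that the read-out responds to an exchange that leaves the count of 4 heavy atoms unchanged while replacing a carbon with an oxygen, adding a hydrogen-bond donor and acceptor, and removing the defined stereocentre. Nothing measured on these compounds explains the step.

A single step cannot tell whether the second hydroxyl, the loss of the terminal carbon or the loss of the stereocentre carries the change, and the one concentration gives no measure of potency. From the compounds shown here alone, it also remains open how the effect would move with an amine or a carboxylic acid in place of the second hydroxyl, or with a longer chain bearing both hydroxyl groups.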